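Swapping the bicyclic amide group and mouse liver stability

This account rests on a few compounds, and the source may have more. Where it says the series, first, only, none or still open, it means among the compounds named here.

Measured so far:
compound 1 `O=C(NCc1ccc(S(=O)(=O)c2ccccc2C(F)(F)F)cc1)c1cc2cnccc2[nH]1` gives 41%
compound 2 `O=C(NCc1ccc(S(=O)(=O)c2ccccc2)cc1)c1cc2ccncc2s1` gives 21%
compound 3 `O=C(NCc1ccc(S(=O)(=O)c2ccccc2)cc1)c1nc2cnccc2[nH]1` gives 7.3%

In an ADME assay on microsomes from liver (Mus musculus) for metabolic stability, read by LC-MS, with a stated time of 30 min, tested at 1 uM (a higher number here means that more of the compound is left, a lower number that less of the compound is left), compound 3 stands lowest of the three; compound 2 lies nearest with 21%, and compound 1 furthest with 41%. Compound 4 `O=C(NCc1ccc(S(=O)(=O)c2ccccc2)cc1)c1cn2ccnc2cn1` is not yet measured and differs from compound 3 in one place: a group of 9 heavy atoms (6 carbon, 3 nitrogen; one five-membered aromatic ring with 2 hetero atoms, one six-membered aromatic ring with 2 hetero atoms) in place of a group of 9 heavy atoms (6 carbon, 3 nitrogen; one five-membered aromatic ring with 2 hetero atoms, one six-membered aromatic ring with 1 hetero atom), on a carbonyl carbon. Among the measured compounds shown here, the only measured step that touches this position is a number 13.7 percentage points lower from compound 2 to compound 3 (beyond the scatter), where another bicyclic group entered on the carbonyl carbon and the remaining fraction fell. For the measured compounds named here, no measured pair shows the present exchange, so its direction stays open. Compound 3 gives 7.3%, leaving little room for a further fall. For compound 4 a modest rise is estimated, a number 7.7 percentage points higher from compound 3 to compound 4 (within the scatter). Compound 4 is therefore expected to give 15%, with a range from 4% to 35%.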

Compound 4, percent of the compound remaining: 13%
Compound 4: middle estimate off by 2 percentage points, on the high side, and the stated range covers the measured number.
By their numbers in this assay, from the lowest: compounds 3, 4 and 2 (each within the scatter of the next, the first and the last beyond it); then compound 1.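

On the carbonyl carbon, joining the same atoms differently, so that a group with 0 hydrogen-bond donors and 3 hydrogen-bond acceptors replaces one with 1 and 2, gives a number 5.7 percentage points higher from compound 3 to compound 4 (within the scatter) in this assay. Against the sulfur-containing group, the same new group gives a number 8 percentage points lower from compound 2 to compound 4 (within the scatter). Compound 4 therefore cannot be told apart from either of these two compounds, even though they lie beyond the scatter of each other.

On these data alone, whether a single-ring group, such as plain phenyl, or a bicyclic group carrying an amine would behave differently on this carbonyl carbon stays open. Nothing at hand gives a measured reason for these steps.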